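Phenyl Replaced by Hydroxy: What the Numbers Allow

The compounds below may be only part of what the source reports. "The series", "measured", "known", "first", "only" and "open" are said of these compounds alone.

In a functional assay on CHO cells for inhibition of transient receptor potential cation channel subfamily V member 1 (Homo sapiens) (on this read-out lower numbers stand for stronger inhibition and higher numbers for weaker inhibition), three compounds have been measured so far. Compound 2 `CC(C)c1ccc(/C=C/C(=O)Nc2ccc3c(c2)OCCO3)cc1` gives 55 nM in this assay. Compound 1 `CN(C)CCC/C(=C\C(=O)Nc1ccc2c(c1)OCCO2)c1ccc(C(C)(C)C)cc1` gives 3900 nM in this assay. Compound 3 `O=C(/C=C/c1ccc(-c2ccccc2)cc1)Nc1ccc2c(c1)OCCO2` returns only a limit, > 4000 nM in this assay, so where it truly stands is not pinned down. Going by the values given here, the single change that separates compound 2 from compound 3 is phenyl in place of isopropyl, and it brought an at least 72-fold higher number from compound 2 to compound 3 (1.86 log units; beyond the scatter); the size of that step is itself only a lower bound, given (the limit of > 4000 nM in this assay, at which 1 of the 3 values shown sits).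

Compound 4 `O=C(/C=C/c1ccc(O)cc1)Nc1ccc2c(c1)OCCO2` is the compound still to be measured in this assay. It differs from compound 3 by hydroxy in place of phenyl on an aromatic carbon. Among the compounds with values here, the only measured step that bears on this place is the one from isopropyl to phenyl, which was large and went toward weaker inhibition. Within the data shown here, a hydroxy group is a different substituent again, and no measured compound carries one, so only a wide range can be set. Compound 3 sits at a limit, so the exact size of the step from it cannot be read off either.

The account expects compound 4 to fall near 1500 nM in this assay, within 200 nM to 6000 nM. The expected step is therefore an at least 2.6-fold lower number from compound 3 to compound 4 (0.42 log units; beyond the scatter).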

Compound 4, half-maximal inhibitory concentration: > 4000 nM
Compound 4: only a limit was reported; the forecaster's own chance of this, stated with the estimate: 35%; middle value at least 2.6-fold (0.42 log units) away from the limit.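

In this assay compound 4 returns only a limit, > 4000 nM. Hydroxy in place of isopropyl on the aromatic carbon brought an at least 72-fold higher number from compound 2 to compound 4 (1.86 log units; beyond the scatter), so among the compounds shown, both the six-carbon phenyl and the one-oxygen hydroxy at this position give a much higher number than isopropyl. The step from compound 3 to compound 4 cannot be read, and no order between phenyl and hydroxy can be given, because both values are limits: the limit of > 4000 nM in this assay, at which 2 of the 4 values shown sit.

The compounds shown leave open where compound 3 and compound 4 truly stand, and so whether phenyl and hydroxy differ at all at this position. They also leave open whether any group other than isopropyl on this aromatic carbon, such as an amine, a chlorine atom or a longer chain like butyl, would keep the number close to that of compound 2, at 55 nM.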